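The source may report more compounds than this note shows. Statements on the series, on what has been measured and on what is new or still open speak of the compounds shown alone.

Going by the values given here, in a functional assay on DU-145 cells (Homo sapiens) for inhibition, read by MTT assay, with stated times of 18 h and 4 h (a lower number here means a stronger inhibitor, a higher number a weaker inhibitor), compound 1 (`CCCCCCCCCCCCCCCCOP(=O)(O)OCCSC(=S)N1CCCCCC1`) gives 17600 nM, the lowest of the three numbers so far. Compound 2 (`CCCCCCCCOP(=O)(O)OCCSC(=S)N1CCCC1`) gives 47100 nM, and compound 3 (`CCCCCCCCCCCCCCCCOP(=O)(O)OCCSC(=S)N1CCN(C)CC1`) gives 49300 nM. Compound 4 (`CCCCCCCCOP(=O)(O)OCCSC(=S)N1CCCCCC1`) is unmeasured and departs from compound 1 by hydrogen in place of octyl on a saturated chain carbon, eight bonds along the chain from an oxygen on an unsaturated carbon: hydrogen in place of octyl on a saturated chain carbon. Among the compounds with values here, the only measured step, a 2.8-fold higher number from compound 1 to compound 3 (0.45 log units; beyond the scatter), leaves the chain untouched, so it gives only a rough scale, and no measured step isolates this change. Compound 4 carries the same chain as compound 2, which gives 47100 nM. A modest move to a higher number, similar in size to that one step, is therefore expected. The estimated step is a 2.4-fold higher number from compound 1 to compound 4 (0.38 log units; beyond the scatter). For compound 4 the expected value is 42000 nM, with an estimated range of 20000 nM to 85000 nM.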

Compound 4, half-maximal inhibitory concentration: 59100 nM
Compound 4: the middle estimate sits 1.4-fold (0.15 log units) below what was measured; measured number inside the range.
By their numbers in this assay, from the lowest: compound 1; then compounds 2, 3 and 4 (each within the scatter of the next).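

In this assay, going by these compounds alone, hydrogen in place of octyl on a saturated chain carbon, eight bonds along the chain from an oxygen on an unsaturated carbon, gives a 3.4-fold higher number from compound 1 to compound 4 (0.53 log units; beyond the scatter), the first direct reading of chain length. On the shorter chain, the ring change gives a 1.3-fold higher number from compound 2 to compound 4 (0.10 log units; within the scatter), so azepan-1-yl and pyrrolidin-1-yl cannot be told apart there. No available evidence accounts for either result.

Open, from the compounds shown here alone, is whether the response to chain length is gradual, which a dodecyl chain would test. Also open, going by these compounds, is how a terminal carboxylic acid on the chain would read.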